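Swapping the Butyl Arm for a Trifluoromethylphenyl Group

The compounds below may be only part of what the source reports. "The series", "measured", "known", "first", "only" and "open" are said of these compounds alone.

Compound 2 `CCCCC(c1ccccc1)n1ccc2cc(/C(C)=C/C(=O)Nc3ccccc3OCCCC(=O)O)ccc21` carries a phenyl on a saturated chain carbon bound to an aromatic nitrogen and a saturated chain carbon. In an assay on Prostate gland for inhibition of steroid 5-alpha-reductase (Rattus norvegicus) (a lower number here means a stronger inhibitor, a higher number a weaker inhibitor), compound 2 gives 9.8 nM, the highest of the two numbers at hand. Its nearest neighbour is compound 1 `CCCCC(C)n1ccc2cc(/C(C)=C/C(=O)Nc3ccccc3OCCCC(=O)O)ccc21`, which in this assay gives 6 nM; the step of a 1.6-fold higher number from compound 1 to compound 2 (0.21 log units; within the scatter), so the two numbers cannot be told apart.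

Compound 3 `C/C(=C\C(=O)Nc1ccccc1OCCCC(=O)O)c1ccc2c(ccn2C(c2ccccc2)c2ccc(C(F)(F)F)cc2)c1` takes the same position one step further: 4-(trifluoromethyl)phenyl in place of butyl on a saturated chain carbon bound to an aromatic carbon and an aromatic nitrogen. Among the measured compounds shown here, the only measured step that bears on this change is the one a 1.6-fold higher number from compound 1 to compound 2 (0.21 log units; within the scatter), in which a ring entering at this carbon left the number essentially where it was. On the strength of the step of a 1.6-fold higher number from compound 1 to compound 2 (0.21 log units; within the scatter), a second ring entering at the same carbon, this time bearing a trifluoromethyl group, is expected to move this assay little, with no clear direction beyond the scatter. Compound 3 is expected to give about 10 nM, within 3 nM to 40 nM. This expectation amounts to the step of a 1.0-fold higher number from compound 2 to compound 3 (0.01 log units; within the scatter).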

Compound 3, half-maximal inhibitory concentration: 8.1 nM
Estimate against measurement, compound 3: 1.2-fold (0.09 log units) above; the measured number falls inside the stated range.
By their numbers in this assay, from the lowest: compounds 1, 3 and 2 (each within the scatter of the next).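

In this assay, the butyl arm on the saturated chain carbon bound to an aromatic carbon and an aromatic nitrogen proves replaceable (a 1.2-fold lower number from compound 2 to compound 3 (0.08 log units; within the scatter)), although 4-(trifluoromethyl)phenyl brings 10 heavy atoms and a six-membered aromatic ring where butyl had 4 heavy atoms and no ring. Read with the earlier step (a 1.6-fold higher number from compound 1 to compound 2 (0.21 log units; within the scatter)), this means that both arms on this carbon have now been exchanged, one in each step, and that neither exchange moved the number beyond the scatter, so among these compounds the position accepts an aromatic ring on either arm and accepts two such rings at once. Nothing at hand explains why the number holds across these changes.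

The compounds shown leave open whether this tolerance reaches groups of another kind on this carbon, such as an amine, a carboxylic acid or a chain longer than butyl. They also leave open whether the trifluoromethyl group contributes anything of its own, as against a chlorine or a plain hydrogen at that place on the ring.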